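Arylsulfonyl in place of ethylcarbamoyl: outlook for compound 4

The source may report more compounds than this note shows. Statements on the series, on what has been measured and on what is new or still open speak of the compounds shown alone.

Measured so far in a functional assay on A2780 cells (Homo sapiens) for antiproliferative activity, read by MTT assay, with a stated time of 48 h (on this read-out higher numbers stand for weaker inhibition and lower numbers for stronger inhibition), as follows
- compound 1 `CCNC(=O)Nc1nc(-c2ccc(OCC)cc2)c(-c2cc(OC)c(OC)c(OC)c2)s1` gives 1.3 nM as a number
- compound 2 `CCOc1ccc(-c2nc(NS(=O)(=O)c3ccccc3C(F)(F)F)sc2-c2cc(OC)c(OC)c(OC)c2)cc1` gives > 5000 nM as a limit of the assay
- compound 3 `CCOc1ccc(-c2nc(NS(=O)(=O)c3ccc(OC)c(F)c3)sc2-c2cc(OC)c(OC)c(OC)c2)cc1` gives > 5000 nM as a limit of the assay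

For the measured compounds named here, compound 1 is the only one with a number, and the other two stand at the limit of > 5000 nM in this assay, at which 2 of the 3 values shown sit, in these notes. Compound 4 `CCOc1ccc(-c2nc(NS(=O)(=O)c3ccc(C)c(C)c3)sc2-c2cc(OC)c(OC)c(OC)c2)cc1` carries (3,4-dimethylphenyl)sulfonyl in place of ethylcarbamoyl on a nitrogen on an aromatic ring. The closest measured step is an at least 3800-fold higher number from compound 1 to compound 3 (3.58 log units; beyond the scatter) for the same kind of exchange. Changing the aryl group on the sulfonyl gives a step that the two limits leave unreadable from compound 2 to compound 3 and so offers no guidance. A large rise in the number is therefore expected in this assay and may well end at the limit again. For compound 4 the expected value is 6000 nM with an estimated range of 1500 nM to 20000 nM in this read-out. This estimate means a 4600-fold higher number from compound 1 to compound 4 (3.66 log units; beyond the scatter) as the expected change.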

Compound 4, half-maximal inhibitory concentration: > 5000 nM
Compound 4 gave a limit, no number (the forecaster's own chance of this, stated with the estimate: 80%); the middle value does not contradict the limit.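

In this assay, (3,4-dimethylphenyl)sulfonyl in place of ethylcarbamoyl gives an at least 3800-fold higher number from compound 1 to compound 4 (3.58 log units; beyond the scatter). This aryl group carries only methyl groups, with neither the fluoro and methoxy of compound 3 nor the trifluoromethyl of compound 2, so among these compounds the loss is not tied to one aryl group. The steps among compound 2, compound 3 and compound 4 cannot be read, each value being a limit of the assay: the limit of > 5000 nM in this assay, at which 3 of the 4 values shown sit.

Still open, going by these compounds, is whether the loss follows the sulfonyl link or the aryl group on it. Methylsulfonyl on the same nitrogen would separate the two.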